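A Second Chloro on the Aryl Ring

The source may hold more compounds than are shown below. What is called first, only, known or untested is meant among the compounds shown, and "the series" means these compounds.

Compound 2 `O=C(/C(=C/c1ccc(Cl)cc1)CCl)c1ccccc1` gives 19000 nM in a functional assay on WiDr cells (Homo sapiens) for inhibition, read by sulforhodamine B assay, with a stated time of 48 h (a lower number here means a stronger inhibitor of growth, a higher number a weaker inhibitor of growth), the higher of the two numbers measured, though only within the scatter of compound 1 `O=C(/C(=C/c1ccccc1)CCl)c1ccccc1`, which gives 18000 nM. Compound 3 `O=C(/C(=C/c1ccc(Cl)cc1Cl)CCl)c1ccccc1` differs from compound 2 by chloro in place of hydrogen on an aromatic carbon. Within the data shown here, the one step that bears on this change, a 1.1-fold higher number from compound 1 to compound 2 (0.02 log units; within the scatter), was the same kind of change, chloro in place of hydrogen on an aromatic carbon, and it stayed within the scatter. No step beyond the scatter is therefore expected in this assay. Compound 3 is estimated at 19000 nM, between 9500 nM and 38000 nM, an expected step of no change at the digits printed from compound 2 to compound 3 (within the scatter).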

Compound 3, concentration for 50% growth inhibition: 13000 nM
Estimate against measurement, compound 3: 1.5-fold (0.16 log units) above; low and high end bracket the measured number.
By their numbers in this assay, from the lowest: compounds 3, 1 and 2 (each within the scatter of the next).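

In this assay, chloro on an aromatic carbon ortho to a large group and meta to a chloro group gives a 1.5-fold lower number from compound 2 to compound 3 (0.16 log units; within the scatter). A second chloro on this ring, at this new place, therefore stays within the scatter, as the first one did. No measurement here speaks to the reason for this result. The compounds shown leave open whether a methoxy group or an amine on this same aromatic carbon would give a step beyond the scatter. They also leave open whether any such step would appear on the other aromatic ring.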